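Swapping Chloro for Iodo Beside the Phenol

This account rests on a few compounds, and the source may have more. Where it says the series, first, only, none or still open, it means among the compounds named here.

Measured compounds:
- compound 1 `COc1cc(CNC(=S)NCC(COC(=O)C(C)(C)C)Cc2ccc(C)c(C)c2)c(Cl)cc1O` gives 24.2 nM in an assay on CHO cells for displacement of a labelled ligand from transient receptor potential cation channel subfamily V member 1 (Rattus norvegicus); a lower number here means a stronger inhibitor, a higher number a weaker inhibitor
- compound 2 `COc1cc(CNC(=S)NC(CCc2ccc(C(C)(C)C)cc2)COC(=O)C(C)(C)C)cc(Cl)c1O` gives 122 nM in this assay

Of the two measured compounds, compound 2 stands at the higher number, which means it is the weaker inhibitor; the gap to compound 1 lies beyond the usual scatter of this assay. The two compounds differ in several places at once, so no single change can be singled out as the cause of that gap.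

Compound 3 `COc1cc(CNC(=S)NC(CCc2ccc(C(C)(C)C)cc2)COC(=O)C(C)(C)C)cc(I)c1O` is not yet measured. It differs from compound 2 in one place only: iodo in place of chloro on an aromatic carbon, on an aromatic carbon ortho to a hydroxy group and meta to a methoxy group. Among the measured compounds shown here, no measured pair shows this swap on its own, so the size of the step is open. A modest improvement, close to the edge of the scatter, is expected for the step from compound 2 to compound 3, a 1.6-fold lower number from compound 2 to compound 3 (0.21 log units; within the scatter). Compound 3 is therefore estimated at 75 nM in this assay, with a range from 25 nM to 220 nM.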

Compound 3, inhibition constant: 214 nM
Compound 3: the middle estimate sits 2.9-fold (0.46 log units) below what was measured; measured number inside the range.
By their numbers in this assay, from the lowest: compound 1; then compounds 2 and 3 (each within the scatter of the next).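

Among the compounds shown here, this is the first pair here that differs in one place only, so it gives the first clean reading of this position. The swap measured in this assay is iodo in place of chloro on an aromatic carbon ortho to a hydroxy group and meta to a methoxy group, and it gives a 1.8-fold higher number from compound 2 to compound 3 (0.24 log units; within the scatter) with nothing else in the structure changed. On this evidence, the two halogens cannot be told apart at this carbon in this compound, and nothing shown explains the result.

As far as these compounds go, what fluoro, bromo or a plain hydrogen would do at this same carbon remains open. So does whether iodo and chloro would also read alike with the different side chain carried by compound 1.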